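The source may report more compounds than this note shows. Statements on the series, on what has been measured and on what is new or still open speak of the compounds shown alone.

Compound 1 `C[C@]1(O)C[C@@](c2cccc(C(F)(F)F)c2)([C@H](O)c2ccccn2)C1` gives 317 mL/min/kg in an ADME assay on liver for metabolic stability, with Liver microsome (Rattus norvegicus) as the target, read by LC-MS, using microsomes, with a stated time of 5 h (on this read-out lower numbers stand for slow clearance and higher numbers for fast clearance), and stands highest of the three measured compounds. Compound 2 `C[C@]1(O)C[C@](c2ccnc(C(F)(F)F)c2)([C@H](O)c2ccccn2)C1` gives 83.3 mL/min/kg in this assay; the difference between the core of compound 1 and the core of compound 2 is not broken down here. Compound 3 `O[C@H](c1ccccn1)[C@]1(c2ccnc(C(F)(F)F)c2)C[C@H](O)C1` gives 50 mL/min/kg in this assay. Compound 3 differs from compound 2 by hydrogen in place of methyl on a saturated ring carbon, and that change gave a 1.7-fold lower number from compound 2 to compound 3 (0.22 log units; within the scatter). Compound 4 `O[C@H](c1ccccn1)[C@]1(c2cccc(C(F)(F)F)c2)C[C@@H](O)C1` has not yet been measured; it differs from compound 1 by hydrogen in place of methyl on a saturated ring carbon, the same change, which occurs twice among the compounds shown. Within the data shown here, the step from compound 1 to compound 4 is expected to be a 1.5-fold lower number from compound 1 to compound 4 (0.18 log units; within the scatter), a small step that rests only on the single earlier instance of this change, a 1.7-fold lower number from compound 2 to compound 3 (0.22 log units; within the scatter). Compound 4 is therefore estimated at 210 mL/min/kg in this assay, with a likely range from 110 mL/min/kg to 400 mL/min/kg.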

Compound 4, clearance: 100 mL/min/kg
The estimate for compound 4 lay 2.1-fold (0.32 log units) above the measured number; measured number below the stated range.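

In this assay, hydrogen in place of methyl on a saturated ring carbon gives a 3.2-fold lower number from compound 1 to compound 4 (0.50 log units; beyond the scatter) on the core of compound 1, and the two instances of this change can be set side by side: the same change on two cores in this assay, a 1.7-fold lower number (0.22 log units; within the scatter) from compound 2 to compound 3 and a 3.2-fold lower number (0.50 log units; beyond the scatter) from compound 1 to compound 4, 1.9-fold (0.28 log units) apart, within the scatter of two such steps. Among these compounds, the change thus carries across these two cores with step sizes that cannot be told apart, although only the step on the core of compound 1 lies beyond the scatter. Two pairs do not show that it would carry to a further core, and they do not explain the step.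

Still open, on these data alone, is how a longer chain such as ethyl, or an amine, at this ring carbon would read in this assay. As far as these compounds go, a carboxylic acid there is equally open.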